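The source may report more compounds than this note shows. Statements on the series, on what has been measured and on what is new or still open speak of the compounds shown alone.

Measured so far:
compound 1 `N#Cc1c(Nc2ccccc2)nc(SCC(=O)Nn2c(COc3ccc(Cl)cc3Cl)nc3ccccc3c2=O)nc1-c1ccccc1`: 78.1%
compound 2 `N#Cc1c(Nc2ccc(Cl)cc2)nc(SCC(=O)Nn2c(COc3ccc(Cl)cc3Cl)nc3ccccc3c2=O)nc1-c1ccccc1`: 59.7%
compound 3 `N#Cc1c(Nc2ccc(O)cc2)nc(SCC(=O)Nn2c(COc3ccc(Cl)cc3Cl)nc3ccccc3c2=O)nc1-c1ccccc1`: 59.7%

In a functional assay on the whole organism (strain albino) for inhibition, with Rattus norvegicus as the target, read by paw edema, with stated times of 1 h and 3 h, at a dose of 100 mg/kg by the oral route (a higher number here means a stronger effect of the compound at the dose given, a lower number a weaker effect), compound 1 stands highest of the three numbers, with compound 2 and compound 3 both lower than compound 1 by more than the scatter. Compound 4 `N#Cc1c(Nc2ccccc2)nc(SCC(=O)Nn2c(COc3ccc(Cl)cc3Cl)nc3ccccc3c2=O)nc1-c1ccc(O)cc1` has not yet been measured. It differs from compound 1 by hydroxy in place of hydrogen on an aromatic carbon. Within the data shown here, two measured steps bear on this, each adding a group on an aromatic carbon of compound 1: a number 18.4 percentage points lower from compound 1 to compound 2 (beyond the scatter) and a number 18.4 percentage points lower from compound 1 to compound 3 (beyond the scatter). Both lowered the read-out by a modest amount, though neither sits at the same place as the change to compound 4. A modest fall is therefore expected; the expected step is a number 15.1 percentage points lower from compound 1 to compound 4 (beyond the scatter). Compound 4 is estimated to give 63%, within a range from 46% to 78%.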

Compound 4, a percentage reported as inhibition, in the whole organism at one dose (the size of the read-out at that dose, not a potency): 91.2%
Compound 4: middle estimate off by 28.2 percentage points, on the low side, outside the stated range (above it).
By their numbers in this assay, from the lowest: compounds 2 and 3 (each within the scatter of the next); then compound 1; then compound 4.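

In this assay, the change from phenyl to 4-hydroxyphenyl gives a number 13.1 percentage points higher from compound 1 to compound 4 (beyond the scatter) and so shows that a hydroxy group at this position can raise the read-out. On a different aromatic ring, the same addition gave a number 18.4 percentage points lower from compound 1 to compound 3 (beyond the scatter) and not a rise, so in these compounds the outcome of adding hydroxy depends on where it stands. Nothing measured here explains this difference between the two places.

From the compounds shown here alone, whether the rise is specific to hydroxy remains open. A methoxy group or an amine at the same position could show this.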